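A furan-2-yl swap near the limit of the assay

A few compounds are considered here, and "the series" means these few. Any claim that something is new, unique, unknown or untested is made for them only; others in the source may bear on it.

In a functional assay on SK-OV-3 cells (Homo sapiens) for antiproliferative activity, read by MTT assay, with a stated time of 24 h (on this read-out lower numbers stand for stronger inhibition and higher numbers for weaker inhibition), compound 1 (`COc1ccc(/C=C/C(=O)c2ccc(OC)c3c2OC(C)(C)C=C3)c(F)c1`) stands at 4880 nM and compound 3 (`COc1ccc(C(=O)/C=C/c2cccc([N+](=O)[O-])c2)c2c1C=CC(C)(C)O2`) at 9720 nM on the same scale. Compound 2 (`COc1ccc(C(=O)/C=C/c2ccc(Br)cc2)c2c1C=CC(C)(C)O2`) shows > 10000 nM as a limit of the assay and not a number. Compound 3 thus sits level with compound 1 within the scatter. Compound 4 (`COc1ccc(C(=O)/C=C/c2ccco2)c2c1C=CC(C)(C)O2`) carries furan-2-yl in place of 3-nitrophenyl on a double-bonded chain carbon bound to a double-bonded chain carbon. The measured steps at this place are modest: a 2.0-fold higher number from compound 1 to compound 3 (0.30 log units; within the scatter) and an at least 2.0-fold higher number from compound 1 to compound 2 (0.31 log units; beyond the scatter) and an at least 1.0-fold lower number from compound 2 to compound 3 (0.01 log units; that floor lies within the scatter) in this assay on the three compounds shown. None of them involves a furan-2-yl group, so no step beyond the scatter is expected. The step expected here is a 1.2-fold lower number from compound 3 to compound 4 (0.08 log units; within the scatter) in size. The estimated value for compound 4 is 8000 nM (expected range 3500 nM to 18000 nM).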

Compound 4, half-maximal inhibitory concentration: > 10000 nM
Compound 4: only a limit was reported; the forecaster's own chance of this, stated with the estimate: 35%; middle value at least 1.2-fold (0.09 log units) away from the limit.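

Compound 4 is reported only as a limit of the assay, as compound 2 is: the limit of > 10000 nM in this assay, at which 2 of the 4 values shown sit.

In this assay, swapping out 3-nitrophenyl gives an at least 1.0-fold higher number from compound 3 to compound 4 (0.01 log units; that floor lies within the scatter), so the two groups cannot be separated, while swapping out 2-fluoro-4-methoxyphenyl gives an at least 2.0-fold higher number from compound 1 to compound 4 (0.31 log units; beyond the scatter), which shows that a five-membered aromatic ring at this place also gives no number better than that of compound 1. The step between the two limits cannot be read.

The compounds shown leave open how far past the limit compound 2 and compound 4 lie, and whether an aminophenyl or carboxyphenyl group at this place would improve on compound 1.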